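Swapping cyclopropyl for ethyl on the ring nitrogen

The compounds below may be only part of what the source reports. "The series", "measured", "known", "first", "only" and "open" are said of these compounds alone.

The shared core of these compounds carries a piperazine chain on one side and a small group on an aromatic nitrogen on the other. Compound 3 `CCCCN1CCN(CCNC(=O)n2c(=O)n(C3CC3)c3ccccc32)CC1` gives 0.46 in a functional assay for agonist activity at 5-hydroxytryptamine receptor 4 (Cavia porcellus) (a lower number here means a smaller maximal response, a higher number a larger maximal response), the highest of the two numbers shown, with compound 1 `CCCN1CCN(CCNC(=O)n2c(=O)n(C3CC3)c3ccccc32)CC1` nearest at 0.41. The step a number 0.050 higher from compound 1 to compound 3 (within the scatter) lies within the scatter and concerns only the chain. Compound 2 `CCn1c(=O)n(C(=O)NCCN2CCN(C)CC2)c2ccccc21` reports a limit, < 0.3, in this assay (the limit of < 0.3 in this assay, at which 1 of the 3 values shown sits), and not a number.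

Compound 4 `CCCCN1CCN(CCNC(=O)n2c(=O)n(CC)c3ccccc32)CC1` differs from compound 3 in one place: ethyl in place of cyclopropyl on an aromatic nitrogen. Among the measured compounds shown here, no measured step touches this position, so the single chain step gives no guide, and compound 2, which also carries ethyl there but differs in a second place as well, offers only its limit. The expectation for compound 4 is therefore a modest fall, a number 0.11 lower from compound 3 to compound 4 (beyond the scatter), with considerable uncertainty. Compound 4 is estimated at 0.35, between 0.25 and 0.47.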

Compound 4, intrinsic activity: the largest response reached, as a fraction of the reference agonist's: < 0.3
Compound 4 ended at the assay's limit; the forecaster's own chance of this, stated with the estimate: 30%; middle value at least 0.050 from the limit.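

The aromatic nitrogen now has a measured step of its own: in this assay, ethyl in place of cyclopropyl gives a number at least 0.16 lower from compound 3 to compound 4 (beyond the scatter). The only readable step among the earlier compounds concerned the chain and lay within the scatter, so this is the one change shown that clearly lowers the maximal response, and it ties the larger response of compound 3 to cyclopropyl at this position. Compound 4 reports a limit and not a number, as compound 2 also does, so the step between these two cannot be read and the full size of the fall stays unknown: the limit of < 0.3 in this assay, at which 2 of the 4 values shown sit.

On these data alone, whether cyclobutyl, isopropyl or a plain hydrogen on this nitrogen would keep the response of compound 3 remains open. Also open, as far as these compounds go, is whether the same swap has a similar effect with the chain of compound 1.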